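This account rests on a few compounds, and the source may have more. Where it says the series, first, only, none or still open, it means among the compounds named here.

Measured in an in vitro ADME assay on microsomes (Homo sapiens) for metabolic stability; on this read-out lower numbers stand for a shorter-lived compound and higher numbers for a longer-lived compound:
- Compound 1 `Cc1c2c(n3c1CCN(C(=O)[C@H](C)N)CC[C@H](C)Nc1cc-3ccc1C(N)=O)CC(C)(C)CC2=O`: 0.433 h
- Compound 2 `Cc1c2c(n3c1CCN(C(=O)CN)C[C@@H](C)[C@H](C)Nc1cc-3ccc1C(N)=O)CC(C)(C)CC2=O`: > 0.5 h

Compound 2 reads > 0.5 h, which is a limit of the assay and not a number. That reading is the limit of > 0.5 h in this assay, at which 1 of the 2 values shown sits. Going by the values given here, compound 1 differs from compound 2 in more than one place, so no single-change step has been measured.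

Compound 3 `Cc1c2c(n3c1CCN(C(=O)[C@@H](N)C(C)C)C[C@@H](C)[C@H](C)Nc1cc-3ccc1C(N)=O)CC(C)(C)CC2=O` is compound 2 with one change, isopropyl in place of hydrogen on a saturated chain carbon bound to an amine nitrogen and a carbonyl carbon. Among the compounds with values here, with compound 1 at 0.433 h as the only exact number available, no shift beyond the usual scatter is expected in this assay, in either direction. The expected step of an at least 1.1-fold lower number from compound 2 to compound 3 (0.04 log units; that floor lies within the scatter) therefore stays small. For compound 3 the estimated half-life is 0.45 h, with an expected range of 0.25 h to 0.8 h.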

Compound 3, half-life: 0.133 h
Estimate against measurement, compound 3: 3.4-fold (0.53 log units) above; measured number outside the range, below it.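

In this assay, the saturated chain carbon bound to an amine nitrogen and a carbonyl carbon proves to be a place where a change moves the read-out: isopropyl in place of hydrogen gives an at least 3.7-fold lower number from compound 2 to compound 3 (0.57 log units; beyond the scatter). This is the only single-change step shown, and it runs toward a shorter-lived compound. Compound 2 reads > 0.5 h, which is a limit of the assay and not a number, so the step fixes a floor and not an exact size: the limit of > 0.5 h in this assay, at which 1 of the 3 values shown sits.

The compounds shown leave open whether ethyl or hydroxymethyl on this same carbon would lower the number as far as isopropyl does. They also leave open whether the step depends on the configuration at this carbon, and the reason for the shift cannot be read from them.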